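The source may report more compounds than this note shows. Statements on the series, on what has been measured and on what is new or still open speak of the compounds shown alone.

Compound 2 `COc1cc(NC(=O)c2csc(-c3c[nH]c4ccc(Br)cc34)n2)cc(OC)c1OC` is the bromo member of the series, bearing the trimethoxy anilide on the shared core. In a functional assay on PC-3 cells (Homo sapiens) for cytotoxicity, read by MTT assay, with a stated time of 48 h, in the absence of a further agent (a higher number here means a weaker inhibitor, a lower number a stronger inhibitor), compound 2 gives > 100000 nM, which is the limit of the assay and not a measured number. Its methoxy counterpart, compound 1 `COc1ccc2[nH]cc(-c3nc(C(=O)Nc4cc(OC)c(OC)c(OC)c4)cs3)c2c1`, gives 94300 nM in this assay. For the measured compounds named here, the one measured step that touches the same aromatic carbon is an at least 1.0-fold higher number from compound 1 to compound 2 (0.02 log units; that floor lies within the scatter), bromo in place of methoxy, and it shows no movement beyond the scatter because the pair sits at the limit of > 100000 nM in this assay, at which 2 of the 3 values shown sit. Compound 3 `COc1ccc(NC(=O)c2csc(-c3c[nH]c4ccc(F)cc34)n2)cc1`, which already carries the fluoro on the shared core but a single methoxy on the anilide, gives > 100000 nM in this assay, again a limit and not a number.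

Compound 4 `COc1cc(NC(=O)c2csc(-c3c[nH]c4ccc(F)cc34)n2)cc(OC)c1OC` differs from compound 2 by fluoro in place of bromo on an aromatic carbon. The measured step from methoxy to bromo at that carbon stayed within the scatter, and the fluoro analogue compound 3 also sits at the floor, so no step beyond the scatter is expected for a number no higher from compound 2 to compound 4 (the limit leaves the size open). For compound 4 the expected value in this assay is therefore 100000 nM, within a range of 50000 nM to 200000 nM, most likely reported only as a limit.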

Compound 4, half-maximal inhibitory concentration: 89000 nM
Beside the measured number, compound 4's estimate is 1.1-fold (0.05 log units) above it; low and high end bracket the measured number.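

In this assay, the step of a 1.1-fold lower number from compound 1 to compound 4 (0.03 log units; within the scatter) gives this aromatic carbon a second measured substituent under the trimethoxy anilide, and it does not separate fluoro from methoxy. The change from 5-bromo-1H-indol-3-yl to 5-fluoro-1H-indol-3-yl reads only as an at least 1.1-fold lower number from compound 2 to compound 4 (0.05 log units; that floor lies within the scatter), so its true size stays unfixed. Compound 2 gives > 100000 nM, which is a limit of the assay and not a number, so the bromo member cannot be ranked against the fluoro or methoxy members: the limit of > 100000 nM in this assay, at which 2 of the 4 values shown sit.

Methoxy and fluoro are so far the only groups at this carbon with numbers, and those numbers lie within the scatter of each other, so it remains open whether any substituent here can shift the read-out beyond the scatter. An amine, a carboxylic acid or a nitrile at this carbon would test that, and a plain hydrogen there would show whether the substituent matters at all.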